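The source may hold more compounds than are shown below. What is called first, only, known or untested is meant among the compounds shown, and "the series" means these compounds.

In a functional assay on MDA-MB-231 cells (Homo sapiens) for inhibition, read by colorimetric assay, with a stated time of 3 days (on this read-out higher numbers stand for weaker inhibition and lower numbers for stronger inhibition), compound 1 (`COc1ccc(-c2cnc(NC(=O)CCCCCCNC(=O)C(O)(O)C(F)(F)F)s2)cc1`) gives 1020 nM and compound 2 (`O=C(CCCCCCNC(=O)C(O)(O)C(F)(F)F)Nc1ncc(-c2ccc(Br)cc2)s1`) gives 790 nM, two numbers within the scatter of each other. Compound 3 (`O=C(CCCCCCNC(=O)C(O)(O)C(F)(F)F)Nc1ncc(-c2ccc(O)cc2)s1`) differs from compound 1 by hydrogen in place of methyl on an oxygen on an aromatic ring. Among the compounds with values here, the only measured change at this end of the series is a 1.3-fold lower number from compound 1 to compound 2 (0.11 log units; within the scatter), bromo in place of methoxy. On that single step, no change beyond the scatter is expected in this assay. For compound 3 the estimated value is 900 nM, with an expected range of 350 nM to 2300 nM. The expected step is a 1.1-fold lower number from compound 1 to compound 3 (0.05 log units; within the scatter).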

Compound 3, half-maximal inhibitory concentration: 1460 nM
Compound 3: middle estimate off by 1.6-fold (0.21 log units), on the low side; measured number inside the range.
By their numbers in this assay, from the lowest: compounds 2, 1 and 3 (each within the scatter of the next).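

In this assay the free hydroxy group adds a third group at this place: methoxy to hydroxy gives a 1.4-fold higher number from compound 1 to compound 3 (0.16 log units; within the scatter) and bromo to hydroxy gives a 1.8-fold higher number from compound 2 to compound 3 (0.27 log units; within the scatter). Removing the methyl from the oxygen on the aromatic ring therefore separates compound 3 from neither earlier compound beyond the scatter, so methoxy, bromo and hydroxy read alike here. Nothing available bears on a cause for this.

From the compounds shown here alone, whether an amine or a carboxylic acid on the aromatic carbon would shift the number beyond the scatter stays open. Going by these compounds, all three compounds carry the same chain, so the effect of a longer chain also stays open.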